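Chain-end ammonium variation: from compound 3 to compound 4

The source may hold more compounds than are shown below. What is called first, only, known or untested is meant among the compounds shown, and "the series" means these compounds.

Measured in an assay on LX2 cells for inhibition of COL1A1 promoter (Homo sapiens), read by a luciferase reporter, with a stated time of 24 h, tested at 20 uM; on this read-out higher numbers stand for a stronger effect at the one concentration tested and lower numbers for a weaker effect:
compound 1 `Cc1ccc(-n2cc(C(=O)Nc3cc(F)cc(F)c3)c(=O)c3ccc(N(C)C)nc32)cc1OCCCCCCC[N+]12CCN(CC1)CC2`: 5.07%
compound 2 `Cc1ccc(-n2cc(C(=O)Nc3cc(F)cc(F)c3)c(=O)c3ccc(N(C)C)nc32)cc1OCCCCCCC[N+]1(C)CCCCC1`: 23.4%
compound 3 `Cc1ccc(-n2cc(C(=O)Nc3cc(F)cc(F)c3)c(=O)c3ccc(N(C)C)nc32)cc1OCCCCCCC[N+]1(C)CCN(C)CC1`: 10.4%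

Compound 3 stands second highest of the three in this assay; its gap to compound 1 is within the scatter, while the step of a number 13 percentage points lower from compound 2 to compound 3 (beyond the scatter) is beyond it.

Compound 4 `Cc1ccc(-n2cc(C(=O)Nc3cc(F)cc(F)c3)c(=O)c3ccc(N(C)C)nc32)cc1OCCCCCCC[N+](C)(C)C1CCCCC1` differs from compound 3 by a group of 9 heavy atoms (8 carbon, 1 nitrogen; one six-membered non-aromatic ring of carbon only) in place of a group of 8 heavy atoms (6 carbon, 2 nitrogen; one six-membered non-aromatic ring with 2 hetero atoms), on a saturated chain carbon, seven bonds along the chain from an oxygen on an aromatic ring. All three measured steps alter this same chain-end group and so bear on the change: a number 18.3 percentage points higher from compound 1 to compound 2 (beyond the scatter), a number 5.3 percentage points higher from compound 1 to compound 3 (within the scatter) and a number 13 percentage points lower from compound 2 to compound 3 (beyond the scatter). The group whose ring carries only one hetero atom, in compound 2, gave the highest number, so a modest rise is expected on moving to a ring of carbon only. Compound 4 is estimated at 20%, range 8% to 32%. The expected step is a number 9.6 percentage points higher from compound 3 to compound 4 (within the scatter).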

Compound 4, a percentage reported as inhibition, at one concentration (the size of the read-out at that concentration, not a potency): 32.3%
The estimate for compound 4 lay 12.3 percentage points below the measured number; measured number outside the range, above it.
By their numbers in this assay, from the lowest: compounds 1 and 3 (each within the scatter of the next); then compounds 2 and 4 (each within the scatter of the next).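

In this assay, the group with one nitrogen and a ring of carbon only gives a number 21.9 percentage points higher from compound 3 to compound 4 (beyond the scatter) and a number 27.2 percentage points higher from compound 1 to compound 4 (beyond the scatter), so across these four compounds the two chain-end groups with one nitrogen sit apart from the two with two nitrogens. Against the group in compound 2, the new group gives a number 8.9 percentage points higher from compound 2 to compound 4 (within the scatter), so the two groups with one nitrogen are not separated. No available evidence bears on this difference.

Going by these compounds, whether a chain-end tertiary amine, which carries no fixed charge, would keep this level remains open. So does the effect of a longer chain.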